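From Fluoro to Hydroxy: What to Expect of Compound 4

A few compounds are considered here, and "the series" means these few. Any claim that something is new, unique, unknown or untested is made for them only; others in the source may bear on it.

Of the compounds shown here, three have so far been measured in a functional assay on PC-3 cells (Homo sapiens) for antiproliferative activity, read by MTT assay, with a stated time of 48 h; on this read-out lower numbers stand for stronger inhibition and higher numbers for weaker inhibition. Compound 1, `COc1ccc(N/C=C\C(=O)c2cn(-c3ccccc3)nc2-c2ccc(F)cc2)cc1`, gives 4600 nM in this assay. Compound 2, `COc1ccc(-c2nn(-c3ccccc3)cc2C(=O)/C=C\Nc2ccc(Cl)cc2)cc1`, gives 3890 nM. Compound 3, `COc1cc(-c2nn(-c3ccccc3)cc2C(=O)/C=C\Nc2ccc(F)cc2)cc(OC)c1OC`, gives 7700 nM; this is the highest of the three numbers, yet its gaps to compound 1 and to compound 2 both lie within the usual scatter of such measurements, so the three compounds cannot be set in any order of strength on this evidence.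

Compound 4, `COc1cc(-c2nn(-c3ccccc3)cc2C(=O)/C=C\Nc2ccc(O)cc2)cc(OC)c1OC`, differs from compound 3 in a single place: hydroxy in place of fluoro on an aromatic carbon. Among the measured compounds shown here, no pair of measured compounds shows this exchange, so the data give no direct reading of its size. Compound 1 and compound 3 carry fluoro at that place and compound 2 carries chloro, and their values sit close together, which suggests that the ring bearing this group tolerates exchange there without large shifts.

The step from compound 3 to compound 4 is therefore expected to be small, a 1.3-fold lower number from compound 3 to compound 4 (0.11 log units; within the scatter), with no direction favoured beyond the scatter. Compound 4 is estimated at 6000 nM in this assay, within a range from 2500 nM to 15000 nM.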

Compound 4, half-maximal inhibitory concentration: 4600 nM
The estimate for compound 4 lay 1.3-fold (0.12 log units) above the measured number, and the stated range covers the measured number.
By their numbers in this assay, from the lowest: compounds 2, 1, 4 and 3 (each within the scatter of the next).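

With the step from fluoro to hydroxy, a 1.7-fold lower number from compound 3 to compound 4 (0.22 log units; within the scatter) in this assay, the compounds shown give their first direct reading of a single exchange at this place, on an aromatic carbon para to a large group. Hydroxy brings one hydrogen-bond donor and one hydrogen-bond acceptor where fluoro counts neither, and this difference in the (4-fluorophenyl)amino to (4-hydroxyphenyl)amino exchange does not move the number beyond the scatter, so this one exchange leaves the antiproliferative reading unresolved from that of its fluoro parent. No measurement in hand offers an explanation for this result.

Still open, on these data alone, is whether any group at this place can shift the number beyond the scatter, for instance an amine, a carboxylic acid or a longer chain such as an ethoxy group in place of the hydroxy. The compounds shown also leave open whether the same exchange from fluoro to hydroxy would read alike on the core of compound 2, which carries a different substitution on its other aromatic ring.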